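The compounds below may be only part of what the source reports. "The series", "measured", "known", "first", "only" and "open" are said of these compounds alone.

Measured in a functional assay on A549 cells (Homo sapiens) for inhibition, read by MTT assay, with a stated time of 72 h; on this read-out higher numbers stand for weaker inhibition and lower numbers for stronger inhibition:
- compound 1 `CO[C@@H]1[C@H]2OC(=O)C[C@H]2O[C@@H]1[C@H](O)c1ccccc1`: 23600 nM
- compound 2 `CO[C@H](c1ccccc1)[C@H]1O[C@@H]2CC(=O)O[C@@H]2[C@H]1O`: 2640 nM
- compound 3 `CO[C@@H]1[C@H]2OC(=O)C[C@H]2O[C@@H]1[C@@H](OC)c1ccccc1`: 25100 nM

Compound 3, at 25100 nM, sits within the scatter of compound 1, at 23600 nM. Compound 2, at 2640 nM, stands beyond the scatter from compound 3, with a clearly lower number and so stronger inhibition.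

The next compound to consider is compound 4 `CO[C@@H]1[C@H]2OC(=O)C[C@H]2O[C@@H]1[C@H](OC)c1ccccc1`. Against compound 3, the change is the two compounds have the same atoms and bonds and differ only in configuration as drawn: 1 of 5 stereo elements differ; a stereocentre at a saturated chain carbon is drawn S in compound 3 and R in compound 4. Among the measured compounds shown here, no measured pair in this small series differs in one place only, so the effect of inverting this stereocentre has not been read directly. The expectation therefore rests on the values alone. Any change in configuration could matter, but nothing measured fixes its direction or size. Compound 2, at 2640 nM, shows that a much lower number is possible among these close relatives, so the expectation leans slightly downward and the range is wider on the low side.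

The expected change is a 1.8-fold lower number from compound 3 to compound 4 (0.25 log units; within the scatter), an estimated shift towards stronger inhibition that stays within the scatter.

For compound 4 the estimated value is 14000 nM, with an expected range of 3000 nM to 40000 nM.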

Compound 4, half-maximal inhibitory concentration: 26300 nM
Compound 4: the middle estimate sits 1.9-fold (0.27 log units) below what was measured; the measured number falls inside the stated range.
By their numbers in this assay, from the lowest: compound 2; then compounds 1, 3 and 4 (each within the scatter of the next).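

In this assay, the stereocentre at the saturated chain carbon can now be read directly, and a 1.0-fold higher number from compound 3 to compound 4 (0.02 log units; within the scatter) means that the S and R drawings cannot be told apart on this read-out, with any difference between these two compounds confined to that single centre: the fact that compounds 3 and 4 differ only in the configuration as drawn

The exchange of methyl in place of hydrogen on an oxygen on a saturated carbon now also reads differently at the two oxygens, with a 1.1-fold higher number from compound 1 to compound 4 (0.05 log units; within the scatter) at one and a 10-fold higher number from compound 2 to compound 4 (1.00 log units; beyond the scatter) at the other. Among these compounds, then, only the second of these oxygens shows a step beyond the scatter, and compound 2 remains the one compound set apart from the rest.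

From the compounds shown here alone, whether the stereocentre is equally silent in compounds with a free hydroxyl, as in compound 1 and compound 2, remains open, since the direct reading comes from a pair with methyl on both oxygens. Also open, going by these compounds, is whether the step at the oxygen free in compound 2 is specific to methyl or would recur with a longer chain such as ethyl, an acetyl ester or an amine in place of that hydroxyl.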